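A few compounds are considered here, and "the series" means these few. Any claim that something is new, unique, unknown or untested is made for them only; others in the source may bear on it.

Measured set, a functional assay on MCF7 cells (Homo sapiens) for cytotoxicity, read by MTT assay, with a stated time of 72 h; a lower number here means a stronger inhibitor of growth, a higher number a weaker inhibitor of growth:
Compound 1 `COc1ccc(CNc2nc([Se]C)nc3ccccc23)cc1`, giving 42200 nM.
Compound 2 `C[Se]c1nc(N)c2ccccc2n1`, giving 46500 nM.
Compound 3 `CSc1ccc(CNc2nc(SC)nc3ncccc23)cc1`, giving 50 nM.

Compound 1 stands second highest of the three numbers. Its nearest neighbour is compound 2, whose number lies within the scatter of that of compound 1, so the two cannot be told apart. Compound 3 stands far from compound 1, with a much lower number well beyond the scatter; compound 3 differs from compound 1 in several places at once, so no single change can be read out of that pair.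

Compound 4 `COc1ccc(CNc2nc([SeH])nc3ccccc23)cc1` is the analogue not yet measured. For the measured compounds named here, its one change from compound 1 is hydrogen in place of methyl on a selenium. Going by the values given here, no measured pair in the set carries this change, or one of the same kind, so there is nothing from which a size or a direction could be taken. Without such a comparison the expectation in this assay is a step no larger than the scatter, in either direction. Compound 4 is therefore expected to give about 40000 nM, with a range from 12000 nM to 130000 nM. The estimate corresponds to a 1.1-fold lower number from compound 1 to compound 4 (0.02 log units; within the scatter), a step expected to fall within the scatter.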

Compound 4, concentration for 50% growth inhibition: 42700 nM
Estimate against measurement, compound 4: 1.1-fold (0.03 log units) below; the range from low to high includes it.
By their numbers in this assay, from the lowest: compound 3; then compounds 1, 4 and 2 (each within the scatter of the next).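

In this assay, for the compounds shown here, hydrogen in place of methyl on the selenium gives a 1.0-fold higher number from compound 1 to compound 4 (0.01 log units; within the scatter), the first reading of any change at this position. On the core of compound 1, methyl and hydrogen on this selenium therefore cannot be told apart, so the methyl is not required for the level of growth inhibition seen with compound 1. Nothing available explains why this step is so small.

From the compounds shown here alone, whether an ethyl group, a longer chain or a chain ending in a carboxylic acid on the selenium would leave the number equally unchanged remains open. Also open, going by these compounds, is whether a step of this kind would stay as small on a more active core, such as that of compound 3 at 50 nM, which carries no selenium.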